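Two Aryloxy Amides Without Effect, and a Third to Test

The source may hold more compounds than are shown below. What is called first, only, known or untested is meant among the compounds shown, and "the series" means these compounds.

Compound 1: `CC(C)(Oc1ccccc1)C(=O)Nc1ccc(OCC(=O)O)c(F)c1` — 3.56%
Compound 2: `CCOc1ccc(OC(C)C(=O)Nc2ccc(OCC(=O)O)c(F)c2)cc1` — 3.56%

In a functional assay on CHO cells for agonist activity at Free fatty acid receptor 1 (Homo sapiens), read by FLIPR, tested at 100 nM (a higher number here means a stronger effect of the compound at the concentration tested, a lower number a weaker effect), compound 1 gives 3.56%. In this assay compound 2 gives 3.56%, level with compound 1 at the digits reported, so the two are within the scatter of each other and no order between them can be stated. Compound 3, `Cc1ccc(C)c(OC(C)C(=O)Nc2ccc(OCC(=O)O)c(F)c2)c1`, differs from compound 2 in one place: 2,5-dimethylphenyl in place of 4-ethoxyphenyl on an oxygen on a saturated carbon.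

Within the data shown here, no step between two measured compounds is available here, so there is nothing in the measured data to say which direction such a change should take. Both measured compounds sit near the bottom of the read-out. Compound 3 is therefore expected to show no step beyond the scatter, a number 1.4 percentage points higher from compound 2 to compound 3 (within the scatter). Compound 3 is estimated at 5%, with a range from 0% to 20%.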

Compound 3, a percentage reported as activity, at one concentration (the size of the read-out at that concentration, not a potency): 18.7%
Compound 3: the middle estimate sits 13.7 percentage points below what was measured, and the stated range covers the measured number.
By their numbers in this assay, from the lowest: compounds 1 and 2 (each within the scatter of the next); then compound 3.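

In this assay, among these compounds, the aryl group on an oxygen on a saturated carbon proves able to move the read-out: 2,5-dimethylphenyl in place of 4-ethoxyphenyl gives a number 15.1 percentage points higher from compound 2 to compound 3 (beyond the scatter), the first step that can be read at all. The swap removes the ring's only oxygen and its hydrogen-bond acceptor and brings in two methyl groups, so this one step cannot separate the loss of the ethoxy group from the gain of the methyl groups. Nothing measured here accounts for the rise.

As far as these compounds go, it remains open whether a single methyl group on the phenyl ring would give part of the step, or whether chlorine atoms could stand in for the two methyl groups. From the compounds shown here alone, the read-out comes from one concentration, so how potent compound 3 is also remains unknown.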